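Pyrrolidin-1-yl on the thiocarbonyl carbon of compound 3

The compounds below may be only part of what the source reports. "The series", "measured", "known", "first", "only" and "open" are said of these compounds alone.

Among the measured compounds shown here, in a functional assay on K562 cells (Homo sapiens) for cytotoxicity, read by MTT assay, with a stated time of 72 h (on this read-out lower numbers stand for stronger inhibition and higher numbers for weaker inhibition), compound 3 (`CC(C)(C)NC(=S)N/N=C1\CC(c2ccc(O)cc2)Oc2cc(O)ccc21`) gives 8900 nM, the lowest of the three numbers so far. Compound 1 (`CC(C)NC(=S)N/N=C1\CC(c2ccc(O)cc2)Oc2cc(O)ccc21`) gives 21300 nM, and compound 2 (`Oc1ccc(C2C/C(=N\NC(=S)N3CCOCC3)c3ccc(O)cc3O2)cc1`) gives 29400 nM. Compound 4 (`Oc1ccc(C2C/C(=N\NC(=S)N3CCCC3)c3ccc(O)cc3O2)cc1`) carries pyrrolidin-1-yl in place of (tert-butyl)amino on a thiocarbonyl carbon. The closest measured change is a 3.3-fold lower number from compound 2 to compound 3 (0.52 log units; beyond the scatter), where morpholin-4-yl gives way to (tert-butyl)amino. Also relevant are a 2.4-fold lower number from compound 1 to compound 3 (0.38 log units; beyond the scatter) and a 1.4-fold higher number from compound 1 to compound 2 (0.14 log units; within the scatter). A modest move to a higher number is therefore expected in this assay, with the estimated step being a 2.5-fold higher number from compound 3 to compound 4 (0.39 log units; beyond the scatter). The expected value for compound 4 is 22000 nM, within an estimated range of 10000 nM to 45000 nM.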

Compound 4, half-maximal inhibitory concentration: 17300 nM
The estimate for compound 4 lay 1.3-fold (0.10 log units) above the measured number; the range from low to high includes it.
By their numbers in this assay, from the lowest: compounds 3, 4, 1 and 2 (each within the scatter of the next, the first and the last beyond it).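

In this assay pyrrolidin-1-yl on the thiocarbonyl carbon cannot be separated from any of the three earlier groups: a 1.9-fold higher number from compound 3 to compound 4 (0.29 log units; within the scatter), a 1.7-fold lower number from compound 2 to compound 4 (0.23 log units; within the scatter) and a 1.2-fold lower number from compound 1 to compound 4 (0.09 log units; within the scatter) all lie within the scatter. Replacing (tert-butyl)amino with this ring, which has no hydrogen-bond donor, thus gives no step beyond the scatter, whereas morpholin-4-yl in compound 2 does. Nothing available here bears on a cause for these steps. Going by these compounds, whether piperidin-1-yl or dimethylamino on this carbon would separate from compound 3 or compound 4 remains open.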